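Exchanging the cyclopentyl of compound 2 for pyridin-3-yl

The compounds below may be only part of what the source reports. "The series", "measured", "known", "first", "only" and "open" are said of these compounds alone.

Measured so far:
compound 1, `O=c1cc(-c2cccnc2)oc2ccc(OCCCCCCN3CCC(O)CC3)cc12`, 194 nM
compound 2, `O=c1cc(C2CCCC2)oc2ccc(OCCCCCCN3CCCCC3)cc12`, 26 nM

Of the two compounds measured in an assay on isolated protein (Cavia porcellus) with Sigma non-opioid intracellular receptor 1 (Homo sapiens) as the target, read by radioligand binding (a higher number here means a weaker inhibitor, a lower number a stronger inhibitor), compound 2 gives the lower number, 26 nM, while compound 1 gives 194 nM; the gap between them lies beyond the usual scatter. Compound 3, `O=c1cc(-c2cccnc2)oc2ccc(OCCCCCCN3CCCCC3)cc12`, has not yet been measured. It differs from compound 2 in one place: pyridin-3-yl in place of cyclopentyl on an aromatic carbon. Compound 1 carries the same pyridin-3-yl and a higher number, though it also differs at the amine; the step of a 3.8-fold higher number from compound 2 to compound 3 (0.59 log units; beyond the scatter) is therefore expected to go upward, by a moderate amount. For compound 3 the estimate is 100 nM, with a plausible range from 30 nM to 330 nM.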

Compound 3, half-maximal inhibitory concentration: 119 nM
Estimate against measurement, compound 3: 1.2-fold (0.08 log units) below, within the range that was stated.
By their numbers in this assay, from the lowest: compound 2; then compounds 3 and 1 (each within the scatter of the next).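

With all else unchanged, pyridin-3-yl in place of cyclopentyl on this aromatic carbon gives a 4.6-fold higher number from compound 2 to compound 3 (0.66 log units; beyond the scatter) in this assay, so this position alone carries a step beyond the scatter. Hydrogen in place of hydroxy on the saturated ring carbon gives a 1.6-fold lower number from compound 1 to compound 3 (0.21 log units; within the scatter) and stays within the scatter. Nothing at hand says why the two groups differ here. Open, going by these compounds, is whether phenyl or cyclohexyl at this position would track compound 2 or compound 3, and whether hydroxy would stay within the scatter alongside cyclopentyl.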